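The source may report more compounds than this note shows. Statements on the series, on what has been measured and on what is new or still open speak of the compounds shown alone.

Series notes on the aryl-amide set. Compound 1 `COc1ccc(-c2cnc(NC(=O)c3ccccn3)n2C)cc1` carries a pyridin-2-yl on the carbonyl carbon of the amide. In a toxicity assay on THP-1 cells (Homo sapiens) for inhibition (a lower number here means that less compound is tolerated, a higher number that more compound is tolerated), compound 1 gives > 100000 nM, which is a limit of the assay and not a number; compound 1 therefore stands only at a bound, as recorded by the limit of > 100000 nM in this assay, at which 1 of the 2 values shown sits. Going by the values given here, the other measured member, compound 2 `Cn1c(-c2ccc(Cl)cc2)cnc1NC(=O)c1ccc(F)cc1`, differs from compound 1 in more than one place, so no single step joins the two; in this assay compound 2 gives 37000 nM.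

Compound 3 `COc1ccc(-c2cnc(NC(=O)c3cnco3)n2C)cc1` has not yet been measured in this assay. It differs from compound 1 by 1,3-oxazol-5-yl in place of pyridin-2-yl on a carbonyl carbon. Among the compounds with values here, no measured step of this kind exists, so the expectation rests on compound 1 alone, whose value is a bound. The step of an at least 1.1-fold lower number from compound 1 to compound 3 (0.04 log units; that floor lies within the scatter) is expected to be none beyond the usual scatter, in either direction. For compound 3 the half-maximal cytotoxic concentration in this assay is estimated at 90000 nM, with a range of 25000 nM to 300000 nM, and a fair chance that only a limit is again reported.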

Compound 3, half-maximal cytotoxic concentration: > 100000 nM
Compound 3: only a limit was reported; the forecaster's own chance of this, stated with the estimate: 55%; at least 1.1-fold (0.04 log units) between middle value and limit.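

Going by these compounds alone, compound 1 and compound 3 both stop at a limit in this assay, so no step from pyridin-2-yl to 1,3-oxazol-5-yl on the carbonyl carbon can be read: the limit of > 100000 nM in this assay, at which 2 of the 3 values shown sit. The compounds shown leave open where either compound lies beyond that limit, and whether this exchange changes the tolerated concentration at all.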